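Adding a Second Methoxy Group: From Compound 3 to Compound 4

The source may hold more compounds than are shown below. What is called first, only, known or untested is meant among the compounds shown, and "the series" means these compounds.

Compound 1 `Cc1ccc(/C=C/C(=O)c2ccccc2NC(=O)NS(=O)(=O)c2ccc(C)cc2)cc1` gives in an ADME assay on the whole organism for cytotoxicity, with Artemia salina as the target, with a stated time of 24 h (a higher number here means that more compound is needed for the effect, a lower number that less compound is needed), a value of 15.3 ug/mL.
Compound 2 `Cc1ccc(S(=O)(=O)NC(=O)Nc2ccccc2C(=O)/C=C/c2ccc(N(C)C)cc2)cc1` gives in this assay a value of 38.1 ug/mL.
Compound 3 `COc1ccc(/C=C/C(=O)c2ccccc2NC(=O)NS(=O)(=O)c2ccc(C)cc2)cc1` gives in this assay a value of 28.1 ug/mL.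

Compound 3 stands second highest of the three numbers in this assay. Its nearest neighbour is compound 2, as shown by a 1.4-fold lower number from compound 2 to compound 3 (0.13 log units; within the scatter), and its furthest is compound 1, as shown by a 1.8-fold higher number from compound 1 to compound 3 (0.26 log units; within the scatter); both differences lie within the scatter.

Compound 4 `COc1ccc(/C=C/C(=O)c2ccccc2NC(=O)NS(=O)(=O)c2ccc(C)cc2)cc1OC` is not yet measured. It differs from compound 3 by methoxy in place of hydrogen on an aromatic carbon.

No measured step adds a second methoxy group; the shown steps all exchange one group for another on the same aromatic carbon. The step of a 1.8-fold higher number from compound 1 to compound 3 (0.26 log units; within the scatter), methoxy in place of methyl, stayed within the scatter, and the step of a 2.5-fold higher number from compound 1 to compound 2 (0.40 log units; beyond the scatter), dimethylamino in place of methyl, was modest. Given this, a step in this assay from compound 3 to compound 4 of no more than the scatter is expected, with the direction uncertain. For compound 4 the estimate is 30 ug/mL, with a range of 15 ug/mL to 60 ug/mL, which means an expected step of a 1.1-fold higher number from compound 3 to compound 4 (0.03 log units; within the scatter).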

Compound 4, concentration for half-maximal effect: 12.9 ug/mL
Estimate against measurement, compound 4: 2.3-fold (0.37 log units) above; the whole stated range lies above it.
By their numbers in this assay, from the lowest: compounds 4, 1, 3 and 2 (each within the scatter of the next, the first and the last beyond it).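

In this assay the step of a 2.2-fold lower number from compound 3 to compound 4 (0.34 log units; beyond the scatter) is the first shown that starts from hydrogen rather than exchanging one group for another, and it lies beyond the scatter, so this ring place, ortho to a methoxy group, is not silent. The 3,4-dimethoxyphenyl group also stands apart from 4-(dimethylamino)phenyl in the step of a 3.0-fold lower number from compound 2 to compound 4 (0.47 log units; beyond the scatter) and yet cannot be told from 4-methylphenyl in the step of a 1.2-fold lower number from compound 1 to compound 4 (0.07 log units; within the scatter) that stays within the scatter. Nothing measured here accounts for the step that the second methoxy group brings.

From the compounds shown here alone, whether a hydroxyl group, a chlorine atom or an ethoxy group in this place would give a like step remains open. So does whether a methoxy group here would give the same step without the first methoxy group present.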